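From hexyl to hydroxymethyl on a shared core

The compounds below may be only part of what the source reports. "The series", "measured", "known", "first", "only" and "open" are said of these compounds alone.

Compound 1 `CCCCCc1ccc(-c2cn(CCCN3C(=O)COc4ccccc43)nn2)cc1` gives 43500 nM
Compound 2 `COc1ccc2cc(-c3cn(CCCN4C(=O)COc5ccccc54)nn3)ccc2c1` gives 1300 nM
Compound 3 `CCCCCCc1cn(CCCN2C(=O)COc3ccccc32)nn1` gives 710 nM

In a functional assay on IMR-32 cells (Homo sapiens) for antiproliferative activity, read by sulforhodamine B assay, with a stated time of 48 h (on this read-out lower numbers stand for stronger inhibition of growth and higher numbers for weaker inhibition of growth), compound 3 and compound 2 sit together at the low end, within the scatter of each other, and compound 1 stands well above them, beyond the scatter. Compound 4 `O=C1COc2ccccc2N1CCCn1cc(CO)nn1` differs from compound 3 in one place (hydroxy in place of pentyl on a saturated chain carbon bound to an aromatic carbon): hydroxy in place of pentyl on a saturated chain carbon bound to an aromatic carbon, or hexyl to hydroxymethyl when cut one bond further out. Among the compounds with values here, no measured pair isolates this change. Compound 3 at 710 nM already lies at the low end, so a rise is more likely than a fall. The expected move is a 21-fold higher number from compound 3 to compound 4 (1.32 log units; beyond the scatter) in the direction of weaker inhibition of growth, beyond the scatter. For compound 4 the estimated value is 15000 nM with an expected range of 3000 nM to 70000 nM in this assay.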

Compound 4, concentration for 50% growth inhibition: 5500 nM
Compound 4: middle estimate off by 2.7-fold (0.44 log units), on the high side; low and high end bracket the measured number.
By their numbers in this assay, from the lowest: compounds 3 and 2 (each within the scatter of the next); then compound 4; then compound 1.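

In this assay, hydroxy in place of pentyl on a saturated chain carbon bound to an aromatic carbon gives a 7.7-fold higher number from compound 3 to compound 4 (0.89 log units; beyond the scatter), so this position responds to the change from hexyl to hydroxymethyl. Even so, growth inhibition is not lost, as compound 4 still gives 5500 nM. Nothing available gives a cause for this step.

The compounds shown do not separate the loss of the pentyl carbons from the entry of the hydroxy. A propyl chain, a methoxymethyl group or an aminomethyl group at this place remains an open case.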